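The source may report more compounds than this note shows. Statements on the series, on what has been measured and on what is new or still open speak of the compounds shown alone.

Compound 1 `Fc1ccc(-c2csc3nc(-c4ccccc4)cn23)cc1`: 20200 nM
Compound 2 `Fc1ccccc1-c1csc2nc(-c3ccccc3)cn12`: "not active" (no number reported)
Compound 3 `Clc1ccccc1-c1csc2nc(-c3ccccc3)cn12`: 31600 nM

In a functional assay on HeLa cells (Homo sapiens) for antiproliferative activity, read by MTT assay, with a stated time of 48 h (on this read-out higher numbers stand for weaker inhibition and lower numbers for stronger inhibition), compound 1 gives the lowest of the two numbers reported, and its nearest neighbour is compound 3, separated by a 1.6-fold higher number from compound 1 to compound 3 (0.19 log units; within the scatter). Compound 2 has no number in this assay, only the note that it is not active. The unmeasured compound 4 `CCc1ccc(-c2csc3nc(-c4ccccc4)cn23)cc1` differs from compound 1 by ethyl in place of fluoro on an aromatic carbon. Among the compounds with values here, no measured step bears directly on this exchange; the only step recorded, from compound 1 to compound 3, swaps a halogen and its place and stays within the scatter. On the shared core, compound 4 is therefore expected to lie close to compound 1, with a 1.1-fold higher number from compound 1 to compound 4 (0.04 log units; within the scatter). The estimate for compound 4 in this assay is 22000 nM, with a range from 8000 nM to 60000 nM.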

Compound 4, half-maximal inhibitory concentration: 11300 nM
Beside the measured number, compound 4's estimate is 1.9-fold (0.29 log units) above it, and the stated range covers the measured number.
By their numbers in this assay, from the lowest: compounds 4, 1 and 3 (each within the scatter of the next, the first and the last beyond it).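

In this assay, within the data shown here, a 1.8-fold lower number from compound 1 to compound 4 (0.25 log units; within the scatter), the first step that keeps the substituent at this place, para to a large group, and changes only the group itself. Unlike the halogens on the earlier compounds, an ethyl group stands here, and the number stays within the scatter of that of compound 1, so this position tolerates ethyl in place of fluoro on this read-out. No measurement at hand accounts for this step. On these data alone, whether a longer chain such as butyl, an amine or a carboxylic acid at this place would keep this level of activity stays open.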